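The source may hold more compounds than are shown below. What is called first, only, known or untested is meant among the compounds shown, and "the series" means these compounds.

Measured compounds in a functional assay on A549 cells (Homo sapiens) for cytotoxicity, read by sulforhodamine B assay, with a stated time of 48 h; a lower number here means a stronger inhibitor of growth, a higher number a weaker inhibitor of growth:

compound 1, `ClCc1ccc(Cn2cnc3c(Cl)ncnc32)cc1`, 1380 nM
compound 2, `ClCc1ccccc1Cn1cnc2ncnc(Cl)c21`, 4460 nM
compound 3, `ClCc1ccc(Cn2cnc3c(Cl)nc(Cl)nc32)cc1`, 18600 nM

Compound 1 gives the lowest of the three numbers. Compound 2 stands second, with a higher number than compound 1 and a lower number than compound 3; both of these gaps lie beyond the scatter. Compound 2 and compound 1 are built from the same atoms joined differently, and the difference between the two cores is not broken down here.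

Among the measured compounds shown here, the one change that is measured in a pair is chloro in place of hydrogen on an aromatic carbon, which gives a 13-fold higher number from compound 1 to compound 3 (1.13 log units; beyond the scatter) in this assay.

Compound 4, `ClCc1ccccc1Cn1cnc2nc(Cl)nc(Cl)c21`, is not yet measured. It carries the same change relative to compound 2: chloro in place of hydrogen on an aromatic carbon. The place is described in the same words for both pairs, so the change is taken as the same one. For the measured compounds named here, on that single precedent, the step expected from compound 2 to compound 4 is a 9.0-fold higher number from compound 2 to compound 4 (0.95 log units; beyond the scatter), resting on the size seen in a 13-fold higher number from compound 1 to compound 3 (1.13 log units; beyond the scatter); with only one measured example, the range is kept wide. Compound 4 is therefore expected to give about 40000 nM in this assay, estimated between 10000 nM and 150000 nM.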

Compound 4, concentration for 50% growth inhibition: 2810 nM
Estimate against measurement, compound 4: 14-fold (1.15 log units) above, outside the stated range (below it).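

In this assay, chloro in place of hydrogen on an aromatic carbon gives a 1.6-fold lower number from compound 2 to compound 4 (0.20 log units; within the scatter), a step that stays within the scatter on the core of compound 2. The size of this change therefore does not carry from one core to the other in this series: the same change on two cores in this assay, a 13-fold higher number (1.13 log units; beyond the scatter) from compound 1 to compound 3 and a 1.6-fold lower number (0.20 log units; within the scatter) from compound 2 to compound 4, 21-fold (1.33 log units) apart, beyond the scatter of two such steps

The two pairs show that a large step on the core of compound 1 gives no basis for expecting the same step on the core of compound 2, but they do not show which structural difference between the two cores accounts for the gap, or how the change would behave on any further core.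

Still open, on these data alone, is whether the two cores also part ways when the aromatic carbon between two ring nitrogen atoms carries an amine or a methoxy group instead of chloro. As far as these compounds go, it is also open whether the gap persists when the chloromethyl group gives way to a hydroxymethyl group or a longer chain.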